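Swapping an Aryl Amide for an Isoxazole in a Cytotoxicity Series

This account rests on a few compounds, and the source may have more. Where it says the series, first, only, none or still open, it means among the compounds named here.

Of the compounds shown here, two from this series have been tested in a toxicity assay on HepG2 cells (Homo sapiens) for inhibition, read by CellTiter-Glo, with a stated time of 48 h; a higher number here means a weaker inhibitor, a lower number a stronger inhibitor. Compound 1 `Cc1cc(C)cc(NC(=O)COc2cc(C)nc3ccc(OC(F)(F)F)cc23)c1` gives > 100000 nM in this assay, which is a limit of the assay rather than a measured number. Compound 2 `COc1ccc2nc(C)cc(OCC(=O)Nc3cc(C)ccc3OC)c2c1` likewise gives > 100000 nM in this assay, again only a limit. Where compound 2 stands is therefore known only as a bound, and it shares this with the one other value shown: the limit of > 100000 nM in this assay, at which 2 of the 2 values shown sit. Among the compounds with values here, no step between two measured compounds is available, so nothing about the effect of a structural change on this measurement can be read from the pair.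

Compound 3 `COc1ccc2nc(C)cc(OCC(=O)Nc3noc(C)c3C)c2c1` has not yet been measured. It differs from compound 2 in one place: 4,5-dimethyl-1,2-oxazol-3-yl in place of 2-methoxy-5-methylphenyl on an amide-type nitrogen. Since both measured compounds sit at the limit, no step beyond the scatter is expected in this assay. The step of a number no higher from compound 2 to compound 3 (the limit leaves the size open) is expected to be none beyond the scatter. Compound 3 is expected to give about 100000 nM in this assay, within a range from 40000 nM to 300000 nM, and most likely to be reported again only as a limit.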

Compound 3, half-maximal inhibitory concentration: > 100000 nM
Compound 3 ended at the assay's limit; the forecaster's own chance of this, stated with the estimate: 85%; the middle value lies on the limit itself.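

Within the data shown here, compound 2 and compound 3 both sit at a limit of the assay, and no step between them can be read in this assay: the limit of > 100000 nM in this assay, at which 3 of the 3 values shown sit. The compounds shown leave open whether 4,5-dimethyl-1,2-oxazol-3-yl and 2-methoxy-5-methylphenyl on the amide-type nitrogen differ at all in this read-out, and whether any compound of the series reaches a measurable value.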